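The source may hold more compounds than are shown below. What is called first, only, known or untested is meant among the compounds shown, and "the series" means these compounds.

The measured compounds, all tested in an assay on HEK-293T cells for displacement of a labelled ligand from corticotropin-releasing factor receptor 1 (Homo sapiens), read by scintillation counting, with a stated time of 2 h; a lower number here means a stronger inhibitor, a higher number a weaker inhibitor:

- Compound 1 `CCCCN(CC)c1cc(C)nc2c1NC(=O)CN2c1ccc(C)cc1C`: compound 1 gives 3.9 nM
- Compound 2 `CCCCN(CC)c1cc(C)nc2c1NC(=O)CN2c1ccc(Br)cc1Cl`: compound 2 gives 2.7 nM
- Compound 3 `CCCCN(CC)c1cc(C)nc2c1NC(=O)CN2c1ccc(Cl)cc1Br`: compound 3 gives 2.5 nM

Compound 3 has the lowest of the three numbers, but its neighbours sit close: a 1.1-fold lower number from compound 2 to compound 3 (0.03 log units; within the scatter) and a 1.6-fold lower number from compound 1 to compound 3 (0.19 log units; within the scatter), both within the scatter, so none of the three can be called stronger than the others.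

Compound 4 `CCCCN(CC)c1cc(C)nc2c1NC(=O)CN2c1ccc(OC)cc1C` is not yet measured. It differs from compound 3 in one place: 4-methoxy-2-methylphenyl in place of 2-bromo-4-chlorophenyl on a nitrogen on an aromatic ring in a ring. Among the compounds with values here, the steps that bear on this change are those that swap the aryl group on the same ring nitrogen. Exchanging the 2,4-dimethylphenyl of compound 1 for a dihalophenyl gave a 1.4-fold lower number from compound 1 to compound 2 (0.16 log units; within the scatter) and a 1.6-fold lower number from compound 1 to compound 3 (0.19 log units; within the scatter), and the two dihalophenyl groups gave a 1.1-fold lower number from compound 2 to compound 3 (0.03 log units; within the scatter); every one of them lies within the scatter. Compound 4 carries a 4-methoxy-2-methylphenyl, closer in kind to the 2,4-dimethylphenyl of compound 1 than to the dihalophenyl of compound 3, so the expected step is a 1.6-fold higher number from compound 3 to compound 4 (0.20 log units; within the scatter), toward the number of compound 1 and not beyond the scatter. Compound 4 is therefore estimated at 4 nM, with a range from 1.5 nM to 12 nM.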

Compound 4, inhibition constant: 4 nM
Compound 4: the middle estimate sits on the measured number at the digits printed; the measured number falls inside the stated range.
By their numbers in this assay, from the lowest: compounds 3, 2, 1 and 4 (each within the scatter of the next).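

Methoxy in place of methyl on an aromatic carbon gives a 1.0-fold higher number from compound 1 to compound 4 (0.01 log units; within the scatter), the first change here that touches only one group on the aryl ring while the rest of the compound stays fixed. Set against the two dihalophenyl groups, the 4-methoxy-2-methylphenyl gives a 1.6-fold higher number from compound 3 to compound 4 (0.20 log units; within the scatter) and a 1.5-fold higher number from compound 2 to compound 4 (0.17 log units; within the scatter), so in this assay an aryl group with an oxygen and a hydrogen-bond acceptor cannot be told apart from those with methyl or halogen alone on this ring nitrogen. Nothing available here accounts for this flat reading.

The compounds shown leave open whether any aryl group at this place moves the number beyond the scatter. Going by these compounds, an amine, a carboxylic acid or a longer chain such as butoxy in place of the methoxy remains untested among them.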